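Swapping Nitro for Iodo: An Expected Non-Event

This account rests on a few compounds, and the source may have more. Where it says the series, first, only, none or still open, it means among the compounds named here.

Of the compounds shown here, three built on a shared core have been tested in an ADME assay on BJ cells (Homo sapiens) for cytotoxicity, with a stated time of 72 h (a higher number here means that more compound is needed for the effect, a lower number that less compound is needed), and none has yet given an exact reading. Compound 1 `COc1ccc(-c2nc3c(c(C)nn3-c3ccccc3)c(-c3ccccc3O)c2C#N)cc1` reads > 23000 nM, which is a limit of the assay and not a number. Compound 2 `COc1cccc(-c2nc3c(c(C)nn3-c3ccccc3)c(-c3ccccc3O)c2C#N)c1` reads > 23000 nM, also a limit. Compound 3 `CCc1ccc(-c2nc3c(c(C)nn3-c3ccccc3)c(-c3ccccc3[N+](=O)[O-])c2C#N)cc1` reads > 20000 nM, again a limit.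

Compound 4 `CCc1ccc(-c2nc3c(c(C)nn3-c3ccccc3)c(-c3ccccc3I)c2C#N)cc1` differs from compound 3 in one place: iodo in place of nitro on an aromatic carbon. This 2-nitrophenyl to 2-iodophenyl swap lies on a six-membered aromatic ring of carbon only, ortho to a large group.

Among the measured compounds shown here, the only measured step is a step that the two limits leave unreadable from compound 1 to compound 2. It replaces 4-methoxyphenyl with 3-methoxyphenyl, so it concerns a different change and offers no size to carry over. With no readable step to point a direction, no shift beyond the scatter is expected in this assay. The expected outcome is a number no higher from compound 3 to compound 4 (the limit leaves the size open). Compound 3 offers only its limit of > 20000 nM as the reference for this expectation.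

For compound 4 the estimated value is 20000 nM, with an expected range from 9000 nM to 32000 nM.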

Compound 4, half-maximal effective concentration: > 20000 nM
Compound 4: no number, only a limit (the forecaster's own chance of this, stated with the estimate: 75%); the middle value sits exactly at the limit.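

In this assay compound 4 gives > 20000 nM, which is a limit and not a number. Compound 3 gives > 20000 nM, also a limit, so no step can be read between compound 3 and compound 4. The compounds shown leave open how much of each is needed for the half-maximal effect, and whether iodo in place of nitro alters that amount.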